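Moving the methoxycarbonyl group around the aryl ring

A few compounds are considered here, and "the series" means these few. Any claim that something is new, unique, unknown or untested is made for them only; others in the source may bear on it.

Compound 1 `CC(C)c1cccc(C(C)C)c1NC(=O)NCC1(c2ccc(F)cc2)CCCC1`: 23 nM
Compound 2 `CC(C)c1cccc(C(C)C)c1NC(=O)NCC1(c2ccc(C(F)(F)F)cc2)CCCC1`: 66 nM
Compound 3 `COC(=O)c1cccc(C2(CNC(=O)Nc3c(C(C)C)cccc3C(C)C)CCCC2)c1`: 34 nM

The three compounds above were measured in an assay on microsomes for inhibition of acyl-CoA:cholesterol acyltransferase (Oryctolagus cuniculus); a higher number here means a weaker inhibitor, a lower number a stronger inhibitor. Compound 3 stands second highest of the three numbers; its nearest neighbour is compound 1, with a 1.5-fold higher number from compound 1 to compound 3 (0.17 log units; within the scatter), and its furthest is compound 2, with a 1.9-fold lower number from compound 2 to compound 3 (0.29 log units; within the scatter). Both of those steps lie within the scatter. Among the measured compounds shown here, the only step beyond the scatter is a 2.9-fold higher number from compound 1 to compound 2 (0.46 log units; beyond the scatter).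

Compound 4 `COC(=O)c1ccc(C2(CNC(=O)Nc3c(C(C)C)cccc3C(C)C)CCCC2)cc1` differs from compound 3 by 4-(methoxycarbonyl)phenyl in place of 3-(methoxycarbonyl)phenyl on a saturated ring carbon. For the measured compounds named here, no measured step moves a group from one position of that aryl ring to another, so none bears directly on this change; the steps that exchange one aryl group for another in this assay stayed within the scatter. Compound 4 is therefore expected to show a 1.2-fold higher number from compound 3 to compound 4 (0.07 log units; within the scatter). The value of compound 4 in this assay is estimated at 40 nM, within a range from 15 nM to 110 nM.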

Compound 4, half-maximal inhibitory concentration: 360 nM
Estimate against measurement, compound 4: 9.0-fold (0.95 log units) below; the measured number lies above the stated range.
By their numbers in this assay, from the lowest: compounds 1, 3 and 2 (each within the scatter of the next, the first and the last beyond it); then compound 4.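

In this assay the placing of the methoxycarbonyl group on the aryl ring proves decisive: 4-(methoxycarbonyl)phenyl in place of 3-(methoxycarbonyl)phenyl gives a large rise in the number (an 11-fold higher number from compound 3 to compound 4 (1.02 log units; beyond the scatter)), although compound 3 had stayed within the scatter of compounds 1 and 2. Without any shift of position, methoxycarbonyl also gives a higher number than trifluoromethyl (a 5.5-fold higher number from compound 2 to compound 4 (0.74 log units; beyond the scatter)) and than fluoro (a 16-fold higher number from compound 1 to compound 4 (1.19 log units; beyond the scatter)). Nothing measured here accounts for these changes. Still open, as far as these compounds go, is whether a carboxylic acid or a nitrile would show the same dependence on position.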